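Removing a trifluoromethyl group from a cell-growth inhibitor

The source may hold more compounds than are shown below. What is called first, only, known or untested is meant among the compounds shown, and "the series" means these compounds.

Compound 1 `O=C(CCCC1CCN(S(=O)(=O)c2ccccc2C(F)(F)F)CC1)NO` has as its result in a functional assay on HCT-116 cells (Homo sapiens) for inhibition, read by resazurin assay, with a stated time of 5 days (on this read-out higher numbers stand for weaker inhibition of growth and lower numbers for stronger inhibition of growth), only "not determined" (no result reported), so it stands without a number. Its relative compound 2 `Cc1cc(S(=O)(=O)N2CCC(CCCC(=O)NO)CC2)cc2ccccc12`, which carries a different aromatic portion on the shared core, gives 17300 nM in this assay. Compound 3 `O=C(CCCC1CCN(S(=O)(=O)c2ccccc2)CC1)NO` differs from compound 1 by hydrogen in place of trifluoromethyl on an aromatic carbon. Going by the values given here, since compound 1 has no value, no step can be anchored, and the size and direction of the change in this assay cannot be judged beyond the scatter. On the strength of compound 2 alone, compound 3 is expected to show about 25000 nM, with a range from 8000 nM to 80000 nM.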

Compound 3, concentration for 50% growth inhibition: 2700 nM
Compound 3: the middle estimate sits 9.3-fold (0.97 log units) above what was measured; measured number outside the range, below it.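

In this assay, going by these compounds alone, compound 1 stands without a number, so no step from it to compound 3 can be read. From the compounds shown here alone, whether swapping trifluoromethyl for hydrogen changes growth inhibition stays open. Nothing shown here offers an explanation for the result of compound 3.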